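The source may report more compounds than this note shows. Statements on the series, on what has been measured and on what is new or still open speak of the compounds shown alone.

Working notes on the series. Compound 1 `COc1ccc(C(=O)NN=C2CC(c3ccccc3)NC(c3ccccc3)C2)cc1` and compound 2 `O=C(NN=C1CC(c2ccccc2)NC(c2ccccc2)C1)c1ccc([N+](=O)[O-])cc1` share one core and differ only in the substituent on the aromatic ring attached to the carbonyl. In a functional assay on A549 cells (Homo sapiens) for cytotoxicity, read by MTT assay, with a stated time of 24 h (a lower number here means a stronger inhibitor, a higher number a weaker inhibitor), compound 1 gives no number, only a limit, > 400000 nM. In this assay compound 2 also gives only a limit, > 400000 nM. The step from compound 1 to compound 2 a step that the two limits leave unreadable from compound 1 to compound 2 cannot be sized, since both values sit at the limit of > 400000 nM in this assay, at which 2 of the 2 values shown sit. Compound 2 therefore stands at the limit of this assay, and nothing places it within the measurable range.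

Compound 3 `O=C(NN=C1CC(c2ccccc2)NC(c2ccccc2)C1)c1ccc(F)cc1C(F)(F)F` differs from compound 2 by 4-fluoro-2-(trifluoromethyl)phenyl in place of 4-nitrophenyl on a carbonyl carbon. Among the compounds with values here, the only measured step bears on an exchange at the same aromatic ring, and its size is unreadable, so no step beyond the scatter has been resolved anywhere. The step expected in this assay a number no higher from compound 2 to compound 3 (the limit leaves the size open) is accordingly small or none beyond the scatter. Compound 3 is estimated to give about 400000 nM in this assay, between 150000 nM and 1000000 nM, with a limit again the likelier outcome.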

Compound 3, half-maximal inhibitory concentration: > 400000 nM
Compound 3 gave a limit, no number (the forecaster's own chance of this, stated with the estimate: 75%); the middle value sits exactly at the limit.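

Compound 3, like compound 1 and compound 2, gives only a limit, so the steps between these three compounds cannot be read: the limit of > 400000 nM in this assay, at which 3 of the 3 values shown sit.

In this assay the compounds shown leave open whether any other group on the aromatic ring attached to the carbonyl, or any change to the shared core, gives a measurable value.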